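A few compounds are considered here, and "the series" means these few. Any claim that something is new, unique, unknown or untested is made for them only; others in the source may bear on it.

Measured compounds:
- compound 1 `O=C(Oc1cccc2cccnc12)c1cc2c(cc1Cl)SC(N(c1ccc(F)cc1)S(=O)(=O)c1ccc(Br)s1)=NS2(=O)=O` — 5100 nM
- compound 2 `COC(=O)c1cc2c(cc1Cl)SC(N(N(C)C)S(=O)(=O)c1ccc(Br)s1)=NS2(=O)=O` — 13700 nM
- compound 3 `CCOC(=O)c1cc2c(cc1Cl)SC(N(c1ccc(OC)cc1)S(=O)(=O)c1ccccc1)=NS2(=O)=O` — 6500 nM

In a functional assay on 5637 cells (Homo sapiens) for cytotoxicity, with a stated time of 96 h (on this read-out higher numbers stand for weaker inhibition of growth and lower numbers for stronger inhibition of growth), compound 1 gives 5100 nM, and compound 3 gives a number that lies within the usual scatter of it, so the two cannot be told apart. Compound 2 gives a higher number, and that gap is beyond the scatter. Compound 4 `O=C(Oc1cccc2cccnc12)c1cc2c(cc1Cl)SC(N(c1ccc(F)cc1)S(=O)(=O)c1ccc(Cl)cc1)=NS2(=O)=O` shares the core of compound 1 and differs from it in one place: 4-chlorophenyl in place of 5-bromothiophen-2-yl on a sulfonyl sulfur. Among the measured compounds shown here, no pair of measured compounds shows this change in isolation, so its effect is not known from these numbers. The step from compound 1 to compound 4 is expected to be small, a 1.1-fold higher number from compound 1 to compound 4 (0.03 log units; within the scatter), with no clear direction beyond the scatter. Compound 4 is therefore estimated at 5500 nM, within a range from 2000 nM to 15000 nM.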

Compound 4, concentration for 50% growth inhibition: 6200 nM
For compound 4 the middle estimate is 1.1-fold (0.05 log units) below the measured one; the measured number falls inside the stated range.
By their numbers in this assay, from the lowest: compounds 1, 4 and 3 (each within the scatter of the next); then compound 2.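

In this assay putting 4-chlorophenyl in place of 5-bromothiophen-2-yl on a sulfonyl sulfur gives a 1.2-fold higher number from compound 1 to compound 4 (0.08 log units; within the scatter) and so leaves the two compounds indistinguishable. Among the compounds shown here, this is the first pair to isolate this change, and it shows that, on this core, the two ring groups cannot be told apart in this read-out. No other measurement bears on this result. Still open, as far as these compounds go, is whether any ring is needed on this sulfonyl sulfur, since a methyl group, a longer alkyl chain or an amine-bearing chain there could give a different number.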